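The source may hold more compounds than are shown below. What is called first, only, known or untested is meant among the compounds shown, and "the series" means these compounds.

Measured in a functional assay on HL-60 cells (Homo sapiens) for inhibition, read by MTT assay, with a stated time of 48 h, tested at 10 uM; on this read-out lower numbers stand for less inhibition of growth and higher numbers for more inhibition of growth at the one concentration tested:
- compound 1 `Cc1cc(=O)c2c(O)c(CN3CCC(c4ccccc4)CC3)c(O)c([C@H]3CCN(C)C[C@H]3O)c2o1`: 26%
- compound 2 `Cc1oc2c([C@H]3CCN(C)C[C@H]3O)c(O)cc(O)c2c(=O)c1C(O)c1cccc(Cl)c1`: 22%

Compound 2, at 22%, stands within the scatter of compound 1 at 26%, so the numbers do not separate these two. Both show modest growth inhibition at the single concentration tested. Compound 3 `Cc1oc2c([C@H]3CCN(C)C[C@H]3O)c(O)cc(O)c2c(=O)c1C(O)c1csc([N+](=O)[O-])c1` keeps the shared core of compound 2 and carries one change, 5-nitrothiophen-3-yl in place of 3-chlorophenyl on a saturated chain carbon bound to an aromatic carbon and an oxygen on a saturated carbon.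

Among the compounds with values here, no measured pair differs in one place only, so the size of this change in this assay has no direct precedent. Within the data shown here, the only guide is that compound 1 at 26% and compound 2 at 22% sit close together despite their different side groups. The expected a number 8 percentage points higher from compound 2 to compound 3 (within the scatter) stays within the scatter, with a slight upward lean and wide uncertainty. For compound 3 the estimated value is 30%, with an expected range of 12% to 55%.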

Compound 3, percent growth inhibition at one concentration: 45%
Estimate against measurement, compound 3: 15 percentage points below, within the range that was stated.
By their numbers in this assay, from the lowest: compounds 2 and 1 (each within the scatter of the next); then compound 3.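

In this assay, within the data shown here, 5-nitrothiophen-3-yl in place of 3-chlorophenyl on a saturated chain carbon bound to an aromatic carbon and an oxygen on a saturated carbon gives a number 23 percentage points higher from compound 2 to compound 3 (beyond the scatter), the first step that can be read as a single change. This position is therefore not silent: the aromatic group carried there can shift growth inhibition at the one concentration tested, which compounds 1 and 2 could not show, as they differ in more than one place and their values stand within the scatter of each other. The change replaces the ring and brings in the nitro group in one move, and nothing available ties the step to any property of either group.

The compounds shown leave open whether the step follows the nitro group or the thiophene ring, and how a phenyl ring bearing a nitro group, a thiophene without one, or an amine in place of the nitro group would read in this assay. Also open, going by these compounds, is whether the step holds at other concentrations, or on the side group of compound 1.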